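The source may hold more compounds than are shown below. What is called first, only, known or untested is meant among the compounds shown, and "the series" means these compounds.

Values in a functional assay on COR-L23 cells (Homo sapiens) for antiproliferative activity, read by CellTiter-Glo, with a stated time of 72 h; on this read-out lower numbers stand for stronger inhibition and higher numbers for weaker inhibition:
- Compound 1 `C[C@@H](c1ccc(NC(=O)N2CC(c3cccnc3)C2)cc1)N1Cc2ccccc2C1=O`: 8 nM
- Compound 2 `CCC(=O)N[C@@H](C)c1ccc(NC(=O)N2CC(c3cccnc3)C2)cc1`: 120 nM
- Compound 3 `C[C@@H](c1ccc(NC(=O)N2CC(c3ccc(N)nc3)C2)cc1)N1Cc2ccccc2C1=O`: 19 nM

Compound 3 sits in the middle of these three numbers, with compound 1 lower and compound 2 higher. Compound 4 `C[C@H](NC(=O)[C@@H]1CCCN1C)c1ccc(NC(=O)N2CC(c3ccc(N)nc3)C2)cc1` comes from compound 3 through a single change: a group of 9 heavy atoms (6 carbon, 2 nitrogen, 1 oxygen; one five-membered non-aromatic ring with 1 hetero atom) in place of a group of 10 heavy atoms (8 carbon, 1 nitrogen, 1 oxygen; one five-membered non-aromatic ring with 1 hetero atom, one six-membered aromatic ring of carbon only), on a saturated chain carbon bound to an aromatic carbon and a saturated chain carbon.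

Among the compounds with values here, the closest precedent is a 15-fold higher number from compound 1 to compound 2 (1.18 log units; beyond the scatter). That step removes the same group from the same place, and the number rises sharply. The other measured step, a 2.4-fold higher number from compound 1 to compound 3 (0.38 log units; beyond the scatter), adds the amino group, which compound 3 and compound 4 both carry, so it says little about this change. Within the data shown here, no measured compound carries the ((1-methylpyrrolidin-2-yl)carbonyl)amino group. It does keep a five-membered non-aromatic ring, so a rise somewhat smaller than the precedent seems plausible, though this is uncertain. The expected change is a clear move towards weaker inhibition, with an estimated size of a 6.3-fold higher number from compound 3 to compound 4 (0.80 log units; beyond the scatter). In this assay, the estimate for compound 4 is 120 nM, with an expected range of 35 nM to 400 nM.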

Compound 4, half-maximal inhibitory concentration: 41 nM
Estimate against measurement, compound 4: 2.9-fold (0.47 log units) above, and the stated range covers the measured number.
By their numbers in this assay, from the lowest: compound 1; then compound 3; then compound 4; then compound 2.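

In this assay, putting ((1-methylpyrrolidin-2-yl)carbonyl)amino on this saturated chain carbon gives a 2.2-fold higher number from compound 3 to compound 4 (0.33 log units; beyond the scatter) and so costs far less than the earlier change at the same place, a 15-fold higher number from compound 1 to compound 2 (1.18 log units; beyond the scatter) in which a group with no ring entered. Compound 4 shows that the six-membered aromatic ring of carbon only in the leaving group can be lost here with just a modest rise in the number, at least in a compound carrying the amino group. The two steps differ in their entering groups and in their starting compounds, and nothing measured here explains the difference in their sizes.

From the compounds shown here alone, it remains open whether the same entering group would give a similarly modest step on compound 1, which lacks the amino group. A piperidine ring in place of the 1-methylpyrrolidine ring, or a simple dimethylamino group on a longer chain, also remains untested among the compounds shown.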